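Three Close Values and One Untested Swap

The compounds below may be only part of what the source reports. "The series", "measured", "known", "first", "only" and "open" are said of these compounds alone.

In a functional assay on HepG2 cells (Homo sapiens) for cytotoxicity, read by MTT assay, with a stated time of 24 h (a lower number here means a stronger inhibitor, a higher number a weaker inhibitor), compound 1 `COc1cc(/C=C2\CN(S(=O)(=O)c3ccc(F)cc3)C/C(=C\c3ccccc3F)C2=O)cc(OC)c1OC` gives 7940 nM, compound 2 `COc1cc(/C=C2\CN(S(=O)(=O)c3ccc(F)cc3)C/C(=C\c3ccccc3F)C2=O)cc(OC)c1` gives 9300 nM, and compound 3 `COc1cc(/C=C2\CN(S(=O)(=O)c3ccc(F)cc3)C/C(=C\c3ccc(C#N)cc3)C2=O)cc(OC)c1OC` gives 4950 nM, so compound 3 stands within the scatter of both others. Compound 4 `COc1cc(/C=C2\CN(S(=O)(=O)c3ccc(F)cc3)C/C(=C\c3cc(OC)c(OC)c(OC)c3)C2=O)cc(OC)c1` has 3,5-dimethoxyphenyl in place of 4-cyanophenyl, a difference counted as 3,5-dimethoxyphenyl in place of 4-cyanophenyl on a double-bonded chain carbon bound to a double-bonded ring carbon. Among the compounds with values here, two measured steps bear on this change. Swapping the group at this place gave a 1.6-fold lower number from compound 1 to compound 3 (0.21 log units; within the scatter), while hydrogen in place of methoxy on an aromatic carbon gave a 1.2-fold higher number from compound 1 to compound 2 (0.07 log units; within the scatter). Both are small, so no change beyond the scatter is expected in this assay, and the estimated shift is a 1.3-fold higher number from compound 3 to compound 4 (0.12 log units; within the scatter). Compound 4 is expected at 6500 nM, with an estimated range of 3000 nM to 14000 nM.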

Compound 4, half-maximal inhibitory concentration: 3890 nM
For compound 4 the middle estimate is 1.7-fold (0.22 log units) above the measured one; the measured number falls inside the stated range.
By their numbers in this assay, from the lowest: compounds 4, 3, 1 and 2 (each within the scatter of the next, the first and the last beyond it).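

In this assay, changes at this position now reach beyond the scatter: 3,4,5-trimethoxyphenyl in place of 2-fluorophenyl gives a 2.4-fold lower number from compound 2 to compound 4 (0.38 log units; beyond the scatter) and 3,5-dimethoxyphenyl in place of 2-fluorophenyl gives a 2.0-fold lower number from compound 1 to compound 4 (0.31 log units; beyond the scatter) in the same direction. Yet 3,5-dimethoxyphenyl in place of 4-cyanophenyl gives only a 1.3-fold lower number from compound 3 to compound 4 (0.10 log units; within the scatter) and stays within the scatter, so those two groups cannot be told apart here. No measurement shown accounts for these differences. The compounds shown leave open how an aromatic ring carrying an amine or a carboxylic acid would behave at this place.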